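Bromopyrimidine in place of cyanopyridine on the shared core

The compounds below may be only part of what the source reports. "The series", "measured", "known", "first", "only" and "open" are said of these compounds alone.

In a functional assay on CHO-K1 cells for antagonist activity at C-X-C chemokine receptor type 3 (Homo sapiens), read by FLIPR and calcium flux (on this read-out lower numbers stand for stronger inhibition and higher numbers for weaker inhibition), compound 1 `C[C@@H]1CN(c2ccc(C(F)(F)F)cn2)[C@@H](C)CN1S(=O)(=O)C[C@]12CC[C@H](CC1=O)C2(C)C` gives 6310 nM. Compound 2 `CC1(C)[C@@H]2CC[C@@]1(CS(=O)(=O)N1CCN(c3ccccn3)CC1)C(=O)C2` reaches only the limit of this assay and gives > 31600 nM. Compound 3 `CC1(C)[C@@H]2CC[C@@]1(CS(=O)(=O)N1CCN(c3ccc(C#N)cn3)CC1)C(=O)C2` likewise gives no number in this assay but only the limit > 31600 nM. The step that the two limits leave unreadable from compound 2 to compound 3 therefore cannot be read. Compound 3 thus stands at the limit, and the limit of > 31600 nM in this assay, at which 2 of the 3 values shown sit, shows how much of this small set sits there; compound 1 alone yields a measured number.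

Compound 4 `CC1(C)[C@@H]2CC[C@@]1(CS(=O)(=O)N1CCN(c3ncc(Br)cn3)CC1)C(=O)C2` differs from compound 3 by 5-bromopyrimidin-2-yl in place of 5-cyanopyridin-2-yl on an amine nitrogen in a ring. For the measured compounds named here, the only measured step at the amine nitrogen in a ring is a step that the two limits leave unreadable from compound 2 to compound 3, which the two limits leave without a size, so neither direction nor size of the change in this assay for this exchange can be drawn from the measured compounds. The expected step is a step that the limit leaves unreadable from compound 3 to compound 4, none beyond the scatter as far as the data allow. Compound 4 is therefore expected to give 40000 nM, with a range from 12000 nM to 120000 nM, and most likely again as a limit rather than a number.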

Compound 4, half-maximal inhibitory concentration: 631 nM
For compound 4 the middle estimate is 63-fold (1.80 log units) above the measured one; the measured number lies below the stated range.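

At this amine nitrogen in a ring, the attached aromatic group clearly matters in this assay: the exchange gives an at least 50-fold lower number from compound 3 to compound 4 (1.69 log units; beyond the scatter) and 5-bromopyrimidin-2-yl in place of pyridin-2-yl gives an at least 50-fold lower number from compound 2 to compound 4 (1.69 log units; beyond the scatter). For the compounds shown here, these are the first readable steps at this place on the shared core, since the step between compound 2 and compound 3 cannot be read. From the compounds shown here alone, both start from limits rather than numbers, so their full size remains unknown: the limit of > 31600 nM in this assay, at which 2 of the 4 values shown sit.

Going by these compounds, the exchange alters both the ring and its substituent, so the shares of the bromine and of the second ring hetero atom stay open. 5-Bromopyridin-2-yl and pyrimidin-2-yl at this place would separate the two.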